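This account rests on a few compounds, and the source may have more. Where it says the series, first, only, none or still open, it means among the compounds named here.

The series rests on a shared core that appears in three measured compounds: compound 1 `COc1cccc(NC(=S)Nc2cccc(C(F)(F)F)c2)c1`, compound 2 `CCOC(=O)c1ccc(NC(=S)Nc2cccc(C(F)(F)F)c2)cc1` and compound 3 `FC(F)(F)c1cccc(NC(=S)NCc2ccco2)c1`. All three were tested in an ADME assay on Vero 76 cells (Chlorocebus sabaeus) for cytotoxicity, read by crystal violet staining, with a stated time of 96 h; a higher number here means that more compound is tolerated, a lower number that less compound is tolerated. There compound 1 gives 20000 nM, compound 2 gives 71000 nM and compound 3 gives 50000 nM. Among these three numbers compound 3 stands second highest: its nearest neighbour is compound 2, whose number lies within the usual scatter of it, while compound 1 sits lowest and lies beyond the scatter from compound 3.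

The next compound to be examined is compound 4 `FC(F)(F)c1cccc(NC(=S)Nc2ccccc2)c1`, which differs from compound 3 in one place: phenyl in place of (furan-2-yl)methyl on an amide-type nitrogen. Going by the values given here, no pair of the measured compounds differs in only one place, so no measured step guides this change directly. What the data do show is that compound 1 and compound 2, which both carry a six-membered ring of carbon only on that nitrogen, give numbers on either side of compound 3 in this assay.

On that basis compound 4 is expected to lie close to compound 3, with a step of a 1.3-fold lower number from compound 3 to compound 4 (0.10 log units; within the scatter) that is estimated to stay within or barely beyond the scatter. The expected value for compound 4 is 40000 nM, estimated to fall between 15000 nM and 100000 nM.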

Compound 4, half-maximal cytotoxic concentration: 39000 nM
For compound 4 the middle estimate is 1.0-fold (0.01 log units) above the measured one, and the stated range covers the measured number.
By their numbers in this assay, from the lowest: compounds 1, 4, 3 and 2 (each within the scatter of the next, the first and the last beyond it).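

In this assay, the first step measured at this position, phenyl in place of (furan-2-yl)methyl on an amide-type nitrogen, stays within the scatter (a 1.3-fold lower number from compound 3 to compound 4 (0.11 log units; within the scatter)), so here a six-membered aromatic ring of carbon only and a five-membered aromatic ring with 1 hetero atom on a carbon link are not told apart. Going by these compounds alone, compound 4 also supplies the first measured steps on that aromatic ring, and both lie within the scatter: hydrogen in place of ethoxycarbonyl on an aromatic carbon (a 1.8-fold lower number from compound 2 to compound 4 (0.26 log units; within the scatter)) and hydrogen in place of methoxy on an aromatic carbon (a 2.0-fold higher number from compound 1 to compound 4 (0.29 log units; within the scatter)). Nothing else measured here bears on what lies behind the size of these steps.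

From the compounds shown here alone, whether a longer chain or a cyclohexyl group on the amide-type nitrogen would also stay within the scatter remains open, as does the outcome for an amine or a carboxylic acid on an aromatic carbon. The compounds shown also leave open how a carbonyl in place of the thiocarbonyl would read in this assay, since all of them keep the thiocarbonyl.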